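Trifluoromethyl in Place of Fluoro on Compound 2

The compounds below may be only part of what the source reports. "The series", "measured", "known", "first", "only" and "open" are said of these compounds alone.

Compound 1 `Oc1cccc(-c2cc(-c3cccc(F)c3)cc(-c3cccc(O)c3)n2)c1` carries two 3-hydroxyphenyl groups and one 3-fluorophenyl group on a shared core; in a functional assay on T47D cells (Homo sapiens) for inhibition (on this read-out lower numbers stand for stronger inhibition and higher numbers for weaker inhibition), compound 1 gives 21300 nM. Moving one hydroxyl gives compound 2 `Oc1ccc(-c2cc(-c3cccc(F)c3)cc(-c3cccc(O)c3)n2)cc1`, and in this assay compound 2 gives 3510 nM. That exchange reads as a 6.1-fold lower number from compound 1 to compound 2 (0.78 log units; beyond the scatter). Compound 3 `Oc1ccc(-c2cc(-c3cccc(F)c3)cc(-c3ccc(O)cc3)n2)cc1` repeats the same exchange on the remaining 3-hydroxyphenyl, and in this assay compound 3 gives only a limit of > 50000 nM. That further exchange reads as an at least 14-fold higher number from compound 2 to compound 3 (1.15 log units; beyond the scatter). Among the two plain numbers, compound 2 holds the lower one. Compound 4 `Oc1ccc(-c2cc(-c3cccc(C(F)(F)F)c3)cc(-c3cccc(O)c3)n2)cc1` is compound 2 with trifluoromethyl in place of fluoro on an aromatic carbon. Neither measured step touches this position: both move a hydroxyl, and they run in opposite directions, so nothing measured here speaks directly to the change. A step within the scatter is therefore expected, a 1.0-fold lower number from compound 2 to compound 4 (0.00 log units; within the scatter). Compound 4 is accordingly estimated at 3500 nM, within a range from 1100 nM to 12000 nM.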

Compound 4, half-maximal inhibitory concentration: 2630 nM
Compound 4: the middle estimate sits 1.3-fold (0.12 log units) above what was measured, within the range that was stated.
By their numbers in this assay, from the lowest: compounds 4 and 2 (each within the scatter of the next); then compound 1. At a limit, above all of these: compound 3.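

The position held by the fluoro group of compound 2 now has a measured step of its own: in this assay, trifluoromethyl in its place gives a 1.3-fold lower number from compound 2 to compound 4 (0.13 log units; within the scatter) and so no real difference. Here 4 heavy atoms enter where 1 left, on the same aromatic carbon, yet the step stays within the scatter, whereas both hydroxyl moves lie beyond it. Nothing available bears on why this position accepts the exchange.

On these data alone, whether this position would accept a group of another kind, such as an amine or a carboxylic acid, stays open. So does whether trifluoromethyl would give the same result with the hydroxyl groups placed as in compound 1 or compound 3.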